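Replacing the Cyanoguanidine Substituent with a Dimethylated Variant

This account rests on a few compounds, and the source may have more. Where it says the series, first, only, none or still open, it means among the compounds named here.

Compound 2 `CC/N=C(/NC#N)NCCCCCn1nc(-c2ccccc2)ccc1=O` gives 60.3 mg/kg in a functional assay on the whole organism with Rattus norvegicus as the target (on this read-out lower numbers stand for an effect already at smaller amounts and higher numbers for an effect only at larger amounts of compound), the lowest of the two numbers measured, with compound 1 `C/N=C(/NC#N)NCCCCCn1nc(-c2ccccc2)ccc1=O` nearest at 76.2 mg/kg. Compound 3 `CN(C)/C(=N/CCCCCCn1nc(-c2ccccc2)ccc1=O)NC#N` carries a group of 9 heavy atoms (5 carbon, 4 nitrogen; no ring) in place of a group of 8 heavy atoms (4 carbon, 4 nitrogen; no ring), on a saturated chain carbon, five bonds along the chain from an aromatic nitrogen. Among the compounds with values here, the only measured step that bears on this, a 1.3-fold lower number from compound 1 to compound 2 (0.10 log units; within the scatter), altered the same group and stayed within the scatter. With no further guidance, a change in this assay beyond the scatter is not expected, so compound 3 is estimated at 55 mg/kg, corresponding to a 1.1-fold lower number from compound 2 to compound 3 (0.04 log units; within the scatter), with a range from 25 mg/kg to 130 mg/kg.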

Compound 3, dose for half-maximal effect: 92.5 mg/kg
Beside the measured number, compound 3's estimate is 1.7-fold (0.23 log units) below it; low and high end bracket the measured number.
By their numbers in this assay, from the lowest: compounds 2, 1 and 3 (each within the scatter of the next).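

In this assay, the group of 9 heavy atoms, with 1 hydrogen-bond donor in place of 2, stays within the scatter of both earlier compounds (a 1.5-fold higher number from compound 2 to compound 3 (0.19 log units; within the scatter); a 1.2-fold higher number from compound 1 to compound 3 (0.08 log units; within the scatter)). So far, then, three different groups at this place, on a saturated chain carbon, five bonds along the chain from an aromatic nitrogen, cannot be told apart on this read-out. No evidence is at hand to explain this result.

As far as these compounds go, whether a clearly different group here, such as a primary amine or a carboxylic acid, would move the number beyond the scatter remains open.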